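Sulfonamide benzylamide series: ring swap at the amide carbonyl

The compounds below may be only part of what the source reports. "The series", "measured", "known", "first", "only" and "open" are said of these compounds alone.

Measured so far in an assay on MDA-MB-231 cells for binding affinity to C-X-C chemokine receptor type 4 (Homo sapiens), read by immunofluorescence and microscopy, with stated times of 10 min and 30 min; a higher number here means that more compound is needed for the effect, a lower number that less compound is needed:
- compound 1 `Cc1ccc(S(=O)(=O)NCc2ccc(CNC(=O)c3ccc([N+](=O)[O-])cc3)cc2)cc1`: 10 nM
- compound 2 `Cc1ccc(S(=O)(=O)NCc2ccc(CNC(=O)c3ccc(F)cc3)cc2)cc1`: 1 nM
- compound 3 `O=C(NCc1ccc(CNS(=O)(=O)c2ccccc2)cc1)c1ccc(F)cc1`: 100 nM

Compound 3 gives the highest number of the three. The two steps that connect the set are a 10-fold lower number from compound 1 to compound 2 (1.00 log units; beyond the scatter) and a 100-fold higher number from compound 2 to compound 3 (2.00 log units; beyond the scatter); both lie beyond the scatter, the second being the larger.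

The next compound is compound 4 `O=C(NCc1ccc(CNS(=O)(=O)c2ccccc2)cc1)c1cccnc1`. It differs from compound 3 as follows: pyridin-3-yl in place of 4-fluorophenyl on a carbonyl carbon.

Neither measured step touches the same part of the molecule in the same way. The step from compound 1 to compound 2 is the closest relative, since it also alters the aromatic ring on the carbonyl carbon, and it was modest in size. The step from compound 2 to compound 3 changes a different ring and does not inform this swap. On that basis a modest shift at most is expected for compound 4 in this assay, with no firm direction, so the estimate stays near the value of compound 3. The estimated step is no change at the digits printed from compound 3 to compound 4 (within the scatter), giving compound 4 an expected value of 100 nM, between 20 nM and 500 nM.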

Compound 4, effective concentration (reported as EC, without a stated level of effect): 10 nM
The estimate for compound 4 lay 10-fold (1.00 log units) above the measured number; the measured number lies below the stated range.
By their numbers in this assay, from the lowest: compound 2; then compounds 1 and 4 (each within the scatter of the next); then compound 3.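

In this assay, the change at the carbonyl carbon gives a 10-fold lower number from compound 3 to compound 4 (1.00 log units; beyond the scatter), so this position responds to replacing the ring itself, not only to changing a substituent on a phenyl ring, as between compound 1 and compound 2. With the unsubstituted benzenesulfonamide held constant, the 4-fluorophenyl group of compound 3 is not needed for the lower number, and pyridin-3-yl gives the lower number of this pair. No measurement shown accounts for this step.

From the compounds shown here alone, it remains open whether the same swap on compound 2, which keeps the methyl group, would give a step of similar size and direction. Also open, going by these compounds, is how pyridin-4-yl, or a phenyl ring carrying a carboxylic acid or an amine, would read on this carbonyl carbon.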